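The source may report more compounds than this note shows. Statements on the series, on what has been measured and on what is new or still open speak of the compounds shown alone.

For the measured compounds named here, in a functional assay on SK-MEL-28 cells (Homo sapiens) for inhibition, read by colorimetric assay and MTT assay, with a stated time of 72 h (a higher number here means a weaker inhibitor, a lower number a stronger inhibitor), compound 1 `C=CCCCCOc1ccccc1-c1cnc(OCCC=C)n1C` gives 17000 nM, the lowest of the three numbers so far. That makes it the strongest inhibitor of the three, as both of its steps lie beyond the scatter. Compound 2 `C=CCCCCOc1ccc(OC)cc1-c1cnc(OCCC=C)n1C` gives 62000 nM, and compound 3 `C=CCCCCOc1ccc(F)cc1-c1cnc(OCCC=C)n1C` gives 82000 nM. Compound 4 `C=CCCCCOc1cc(F)ccc1-c1cnc(OCCC=C)n1C` has not yet been measured. It differs from compound 1 as follows: fluoro in place of hydrogen on an aromatic carbon. This is fluoro in place of hydrogen on an aromatic carbon, meta to a (hex-5-en-1-yl)oxy group and para to a large group. Going by the values given here, two measured steps bear on this change. Methoxy on the same ring gave a 3.6-fold higher number from compound 1 to compound 2 (0.56 log units; beyond the scatter), and fluoro on a different carbon of that ring gave a 4.8-fold higher number from compound 1 to compound 3 (0.68 log units; beyond the scatter). Both rises are modest, and a 1.3-fold higher number from compound 2 to compound 3 (0.12 log units; within the scatter) stays within the scatter. Neither step tests this new place, so a modest rise in this assay is expected, with real uncertainty. The expected outcome is a 2.6-fold higher number from compound 1 to compound 4 (0.42 log units; beyond the scatter). For compound 4 the estimated value is 45000 nM, with an expected range of 15000 nM to 110000 nM.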

Compound 4, half-maximal inhibitory concentration: 83000 nM
Beside the measured number, compound 4's estimate is 1.8-fold (0.27 log units) below it, within the range that was stated.
By their numbers in this assay, from the lowest: compound 1; then compounds 2, 3 and 4 (each within the scatter of the next).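

In this assay a fluoro group at this new place, meta to a (hex-5-en-1-yl)oxy group and para to a large group, gives a 4.9-fold higher number from compound 1 to compound 4 (0.69 log units; beyond the scatter) and so a weaker inhibitor. With fluoro on a different carbon of the same ring, compound 3 gives 82000 nM and compound 4 gives 83000 nM in this assay with the two numbers within the scatter of each other. Moving the fluoro between these two carbons therefore makes no visible difference here, and the loss against compound 1 appears at both places.

As far as these compounds go, whether an amine or a carboxylic acid at this place would bring the number back towards that of compound 1 stays open. No measurement shown here explains the loss seen with fluoro.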